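The source may hold more compounds than are shown below. What is called first, only, known or untested is meant among the compounds shown, and "the series" means these compounds.

Of the compounds shown here, two sharing one core have been tested in an ADME assay on Huh-7 cells (Homo sapiens) for cytotoxicity; on this read-out higher numbers stand for lower toxicity in this test and lower numbers for higher toxicity in this test. Compound 1 `Cc1ccccc1-c1nn(-c2ccc(Cl)cc2)cc1CNCCN1CCN(C)CC1` carries a chloro group on the outer benzene ring, and in this assay compound 1 gives 17000 nM. Compound 2 `Cc1ccccc1-c1nn(-c2ccc(C(F)(F)F)cc2)cc1CNCCN1CCN(C)CC1` carries a trifluoromethyl group in the same place, and in this assay compound 2 gives 11000 nM. For the measured compounds named here, compound 2 therefore holds the lowest of the two numbers so far, with compound 1 its only neighbour, and the difference between the two is small: a 1.5-fold lower number from compound 1 to compound 2 (0.19 log units; within the scatter).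

Compound 3 `Cc1ccccc1-c1nn(-c2ccc([N+](=O)[O-])cc2)cc1CNCCN1CCN(C)CC1` is not yet measured. The change from compound 2 to compound 3 is nitro in place of trifluoromethyl on an aromatic carbon. Going by the values given here, the one measured step that bears on this, the swap of chloro for trifluoromethyl at the same position, gave a 1.5-fold lower number from compound 1 to compound 2 (0.19 log units; within the scatter), so a third substituent at this position is expected to leave the number about where it is, with no shift beyond the scatter. The step from compound 2 to compound 3 is therefore estimated as a 1.1-fold higher number from compound 2 to compound 3 (0.04 log units; within the scatter). For compound 3 in this assay the expected value is 12000 nM, with a range from 5000 nM to 30000 nM.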

Compound 3, half-maximal cytotoxic concentration: > 20000 nM
Compound 3 gave a limit, no number (the forecaster's own chance of this, stated with the estimate: 15%); middle value at least 1.6-fold (0.22 log units) from the limit.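

In this assay compound 3 gives a limit of the assay and not a number: the limit of > 20000 nM in this assay, at which 1 of the 3 values shown sits.

For the compounds shown here, this makes nitro the first of the three groups at this position to end at a limit, whereas chloro and trifluoromethyl each gave a number. The step to nitro from trifluoromethyl reads an at least 1.8-fold higher number from compound 2 to compound 3 (0.25 log units; that floor lies within the scatter), and the step to nitro from chloro reads an at least 1.1-fold higher number from compound 1 to compound 3 (0.07 log units; that floor lies within the scatter). As far as these compounds go, each of these is only a floor, so the true size of either step stays unknown, and the data do not yet separate the three groups at this position by more than the usual scatter, though a larger step for nitro remains possible.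

The compounds shown leave open whether an amine, a carboxylic acid or a simple methyl group on this same aromatic carbon would give a number clearly apart from those of chloro and trifluoromethyl. They also leave open whether any change at this position moves this read-out beyond the scatter, since every step seen here so far either lies within it or has a floor that does.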